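Trimming the Sulfonyl Aryl Group to a Methyl

The source may report more compounds than this note shows. Statements on the series, on what has been measured and on what is new or still open speak of the compounds shown alone.

In an assay on isolated protein for inhibition of malate dehydrogenase, mitochondrial (Sus scrofa), with stated times of 45 min and 30 min (on this read-out higher numbers stand for weaker inhibition and lower numbers for stronger inhibition), compound 3 `O=S(=O)(Nc1ccc(-c2nc3ccccc3o2)cc1)c1cccc(Cl)c1` gives only a limit, > 63000 nM, not a number. Compound 1 `O=S(=O)(Nc1ccc(-c2nc3ccccc3o2)cc1)c1cccc(F)c1` likewise reaches only the limit > 63000 nM. Compound 2 `O=S(=O)(Nc1ccc(-c2nc3ccccc3o2)cc1)c1ccccc1Cl` also stays at the limit > 63000 nM. All three values sit at the limit of > 63000 nM in this assay, at which 3 of the 3 values shown sit, so the steps a step that the two limits leave unreadable from compound 1 to compound 3 and a step that the two limits leave unreadable from compound 2 to compound 3 cannot be sized. Compound 4 `CS(=O)(=O)Nc1ccc(-c2nc3ccccc3o2)cc1` differs from compound 3 by methyl in place of 3-chlorophenyl on a sulfonyl sulfur. The measured steps on the sulfonyl group show no readable change in this assay, so no step beyond the scatter is expected, and the step from compound 3 to compound 4 is estimated as a step that the limit leaves unreadable from compound 3 to compound 4. Compound 4 is expected to give about 100000 nM, in a range from 50000 nM to 300000 nM, most likely again only as a limit.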

Compound 4, half-maximal inhibitory concentration: > 63000 nM
Compound 4 was reported as a limit; the forecaster's own chance of this, stated with the estimate: 90%; the middle value does not contradict the limit.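

For the compounds shown here, no step from compound 1, compound 2 or compound 3 to compound 4 can be read, because all four stop at one shared value: the limit of > 63000 nM in this assay, at which 4 of the 4 values shown sit. The compounds shown leave open whether any group on the sulfonyl sulfur changes inhibition in this assay.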